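Swapping the aryl ring on a shared core: compound 4

A few compounds are considered here, and "the series" means these few. Any claim that something is new, unique, unknown or untested is made for them only; others in the source may bear on it.

Three compounds share one core and differ only in the aromatic ring attached to the double-bonded chain carbon. Compound 1 `O=C1/C(=C/c2ccc(Br)cc2)NS(=O)(=O)c2ccccc21` carries a 4-bromophenyl ring, compound 2 `O=C1/C(=C/c2cccc(Cl)c2)NS(=O)(=O)c2ccccc21` a 3-chlorophenyl ring, and compound 3 `O=C1/C(=C/c2ccc(F)cc2)NS(=O)(=O)c2ccccc21` a 4-fluorophenyl ring. In an assay for inhibition of alkaline phosphatase, tissue-nonspecific isozyme (Homo sapiens), read by spectrophotometry, with stated times of 10 min and 20 min (on this read-out higher numbers stand for weaker inhibition and lower numbers for stronger inhibition), compound 1 gives 1430 nM and compound 3 gives 1350 nM, so that a 1.1-fold lower number from compound 1 to compound 3 (0.03 log units; within the scatter). Compound 2 yields only a limit of the method, > 200000 nM (the limit of > 200000 nM in this assay, at which 1 of the 3 values shown sits). Compound 3 thus sits at the lowest number of the two that were measured outright, with compound 1 within the usual scatter of it.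

Compound 4 `Cc1ccccc1/C=C1\NS(=O)(=O)c2ccccc2C1=O` has not been measured. It differs from compound 3 in that (2-methylphenyl in place of 4-fluorophenyl on a double-bonded chain carbon bound to a double-bonded ring carbon). Within the data shown here, the steps that bear on this are those that move the ring substituent away from the 4-position: an at least 130-fold higher number from compound 1 to compound 2 (2.14 log units; beyond the scatter) and an at least 140-fold lower number from compound 2 to compound 3 (2.17 log units; beyond the scatter), both large. Among the measured compounds shown here, no compound carrying a 2-methylphenyl ring has a value here, so the size of the change is uncertain. For compound 4 a higher number than for compound 3 is expected, and the step that this expectation means is estimated as an 11-fold higher number from compound 3 to compound 4 (1.05 log units; beyond the scatter). Compound 4 is estimated at 15000 nM, within 1500 nM to 200000 nM.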

Compound 4, half-maximal inhibitory concentration: 2360 nM
Estimate against measurement, compound 4: 6.4-fold (0.80 log units) above; measured number inside the range.
By their numbers in this assay, from the lowest: compounds 3, 1 and 4 (each within the scatter of the next). At a limit, above all of these: compound 2.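

In this assay, a ring with no halogen at all serves at this place as well as the halogen-bearing rings: a 1.7-fold higher number from compound 3 to compound 4 (0.24 log units; within the scatter), and a 1.7-fold higher number from compound 1 to compound 4 (0.22 log units; within the scatter), both within the scatter. The 2-methylphenyl ring thus stays with 4-bromophenyl and 4-fluorophenyl, leaving compound 2 alone on the far side of a large gap: an at least 84-fold lower number from compound 2 to compound 4 (1.92 log units; beyond the scatter). That gap rests on a limit of the assay and not on a number: the limit of > 200000 nM in this assay, at which 1 of the 4 values shown sits.

The compounds shown leave open whether the loss in compound 2 goes with the chloro group or with where it sits on the ring, as a 3-methylphenyl ring and a 2-chlorophenyl ring lie outside this set. From the compounds shown here alone, how a phenyl ring carrying an amine or a carboxylic acid would behave at this place is also open.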